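Three limits and one propargyl change

The compounds below may be only part of what the source reports. "The series", "measured", "known", "first", "only" and "open" are said of these compounds alone.

Compound 1 `C#CCNC1CCc2c(OCCCN3CCN(c4cccc5c4ccn5Cc4cccc(Cl)c4)CC3)cccc21` gives only an assay limit in an assay on BTI cells for inhibition of Amine oxidase [flavin-containing] B (Homo sapiens), read by fluorescence, with stated times of 30 min and 1 h; a lower number here means a stronger inhibitor, a higher number a weaker inhibitor: > 1000 nM.
Compound 2 `C[C@H](NCc1ccc(OCCCN2CCN(c3cccc4c3ccn4Cc3cccc(Cl)c3)CC2)cc1)C(N)=O` gives only a limit in this assay: > 1000 nM.
Compound 3 `C[C@H](NCc1ccc(OCCCCN2CCN(c3cccc4c3ccn4S(=O)(=O)c3ccccc3)CC2)cc1)C(N)=O` gives only a limit in this assay: > 1000 nM.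

Within the data shown here, all three measured compounds sit at the limit of > 1000 nM in this assay, at which 3 of the 3 values shown sit, so compound 3 stands nowhere on a numerical scale: only its limit is known, and no step between measured compounds can be read. Compound 4 `C#CCN(C)Cc1ccc(OCCCCN2CCN(c3cccc4c3ccn4S(=O)(=O)c3ccccc3)CC2)cc1` carries methyl(propargyl)amino in place of (1-carbamoylethyl)amino on a saturated chain carbon bound to an aromatic carbon. Compound 1 already holds a propargyl group and still reports only a limit, > 1000 nM, so that group alone gives no reason to expect a large move. A modest gain is nevertheless expected for compound 4, as the step of an at least 1.2-fold lower number from compound 3 to compound 4 (0.09 log units; that floor lies within the scatter), with a real chance that compound 4 again returns only a limit. Compound 4 is estimated at 800 nM, between 150 nM and 5000 nM.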

Compound 4, half-maximal inhibitory concentration: > 1000 nM
Compound 4: a limit, no number; the forecaster's own chance of this, stated with the estimate: 45%; middle value at least 1.2-fold (0.09 log units) away from the limit.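

No step can be read from compound 3 to compound 4, since both give only a limit: the limit of > 1000 nM in this assay, at which 4 of the 4 values shown sit.

The compounds shown leave open how methyl(propargyl)amino and (1-carbamoylethyl)amino compare in this assay, and what number any of these compounds would reach.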